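Swapping the pyridine ring for a phenyl on the amide

The source may report more compounds than this note shows. Statements on the series, on what has been measured and on what is new or still open speak of the compounds shown alone.

Measured so far:
compound 1 `O=C(NCc1ccc(CNS(=O)(=O)c2ccccc2)cc1)c1cccnc1` — 53%
compound 2 `Cc1ccc(S(=O)(=O)NCc2ccc(CNC(=O)c3ccccc3Cl)cc2)cc1` — 26%

Of the compounds shown here, two have been tested in a functional assay on the whole organism for inhibition, with Mus musculus as the target, with stated times of 30 min and 2 h, at a dose of 10 mg/kg by the intraperitoneal route; a lower number here means less inhibition, a higher number more inhibition at the dose given (going by the name of the read-out). Compound 1 gives 53%, the higher of the two numbers. Compound 2 gives 26%, a gap beyond the scatter, but compound 2 differs from compound 1 in two places at once, so no single change can be read from that pair.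

Compound 3 `O=C(NCc1ccc(CNS(=O)(=O)c2ccccc2)cc1)c1ccccc1` has not been measured. It differs from compound 1 in one place: phenyl in place of pyridin-3-yl on a carbonyl carbon. The change removes the one hydrogen-bond acceptor that the pyridine ring carries on the carbonyl carbon.

Going by the values given here, nothing among the measured compounds isolates this change, so the expected step of a number 11 percentage points lower from compound 1 to compound 3 (beyond the scatter) is taken as a modest decrease, possibly within the scatter. Compound 3 is therefore estimated at 42% in this assay, with a range from 20% to 65%.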

Compound 3, a percentage reported as inhibition, in the whole organism at one dose (the size of the read-out at that dose, not a potency): 62%
Compound 3: middle estimate off by 20 percentage points, on the low side; the range from low to high includes it.
By their numbers in this assay, from the lowest: compound 2; then compounds 1 and 3 (each within the scatter of the next).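

In this assay, going by these compounds alone, phenyl in place of pyridin-3-yl on a carbonyl carbon gives a number 9 percentage points higher from compound 1 to compound 3 (within the scatter), the first change here that can be read on its own, and compound 1 and compound 3 cannot be told apart. The ring nitrogen of pyridin-3-yl, with the hydrogen-bond acceptor counted for it, can therefore be replaced by carbon at this position without a shift beyond the usual scatter at this dose. Nothing at hand explains this result.

From the compounds shown here alone, it remains open whether a group of another kind on this carbonyl carbon, such as cyclohexyl or a short chain ending in an amine, would shift the read-out beyond the scatter. Going by these compounds, each number also reflects a single dose rather than a potency, so any difference between compound 1 and compound 3 at other doses remains unknown.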